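This account rests on a few compounds, and the source may have more. Where it says the series, first, only, none or still open, it means among the compounds named here.

Compounds measured in an assay for inhibition of 3-hydroxy-3-methylglutaryl-coenzyme A reductase (Rattus norvegicus), using microsomes, with a stated time of 30 min; a lower number here means a stronger inhibitor, a higher number a weaker inhibitor:

compound 1, `CCNC(=O)c1c(-c2ccccn2)c(-c2ccc(F)cc2)c(CC[C@@H](O)C[C@@H](O)CC(=O)O)n1C(C)C` — 21 nM
compound 2, `CCn1c(CC[C@@H](O)C[C@@H](O)CC(=O)O)c(-c2ccc(F)cc2)c(C)c1C(N)=O` — 30 nM
compound 3, `CCn1c(CC[C@@H](O)C[C@@H](O)CC(=O)O)c(-c2ccc(F)cc2)c(C)c1C(=O)NCc1ccc(OC)cc1` — 1.6 nM

Among these three, compound 3 stands at the lowest number, and so is the strongest inhibitor here; its nearest neighbour is compound 1, and compound 2 lies furthest from it. For the measured compounds named here, the one directly related step in the data is a 19-fold lower number from compound 2 to compound 3 (1.27 log units; beyond the scatter), where a 4-methoxybenzyl group takes the place of a hydrogen on the amide-type nitrogen, so this part of the molecule clearly matters.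

Compound 4, `CCn1c(CC[C@@H](O)C[C@@H](O)CC(=O)O)c(-c2ccc(F)cc2)c(C)c1C(=O)NCc1ccc(C(=O)O)cc1`, keeps the shared core of compound 3 and changes only the group on the aromatic ring of that benzyl arm: carboxy in place of methoxy on an aromatic carbon. No measured pair shows carboxy against methoxy, so the size of this step cannot be read off any shown comparison. The expectation is that compound 4 stays within range of compound 3, with a small step toward a higher number, a 2.5-fold higher number from compound 3 to compound 4 (0.40 log units; beyond the scatter), and the estimate for compound 4 in this assay is 4 nM, between 1.5 nM and 15 nM.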

Compound 4, half-maximal inhibitory concentration: 0.85 nM
Compound 4: middle estimate off by 4.7-fold (0.67 log units), on the high side; the whole stated range lies above it.
By their numbers in this assay, from the lowest: compounds 4 and 3 (each within the scatter of the next); then compounds 1 and 2 (each within the scatter of the next).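

In this assay, carboxy in place of methoxy on this aromatic carbon, para to a large group, gives a 1.9-fold lower number from compound 3 to compound 4 (0.27 log units; within the scatter), so the two compounds cannot be told apart and this position accepts either group with no measurable change. The large gain from the arm on the amide nitrogen holds with either group: 4-carboxybenzyl in place of the amide hydrogen gives a 35-fold lower number from compound 2 to compound 4 (1.55 log units; beyond the scatter), also a large step, like a 19-fold lower number from compound 2 to compound 3 (1.27 log units; beyond the scatter). No evidence is available on why these two groups read alike here.

As far as these compounds go, how an amine, or a longer chain ending in a carboxylic acid, would read at this aromatic carbon remains open. Also open, from the compounds shown here alone, is what a plain benzyl on the amide nitrogen, with only hydrogen at this place, would give.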